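Chloro retained, isoxazole swapped for isopropoxy

The source may report more compounds than this note shows. Statements on the series, on what has been measured and on what is new or still open speak of the compounds shown alone.

In an assay on Sf9 cells for inhibition of histone-lysine N-methyltransferase EZH2 (Homo sapiens), read by scintillation counting, with a stated time of 60 min, in the presence of a further agent that is not named here (a higher number here means a weaker inhibitor, a lower number a stronger inhibitor), compound 2 `Cc1cc(C)c(CN2CCc3ccc(-c4c(C)noc4C)c(Cl)c3C2=O)c(=O)[nH]1` gives 3.2 nM, the lowest of the two numbers recorded; compound 1 `Cc1cc(C)c(CN2CCc3ccc(OC(C)C)cc3C2=O)c(=O)[nH]1` gives 8100 nM, a gap well beyond the scatter. Compound 3 `Cc1cc(C)c(CN2CCc3ccc(OC(C)C)c(Cl)c3C2=O)c(=O)[nH]1` remains to be measured in this assay. It differs from compound 2 by isopropoxy in place of 3,5-dimethyl-1,2-oxazol-4-yl on an aromatic carbon. Since compound 1, which also carries the isopropoxy group, gives 8100 nM, a large step toward weaker inhibition is expected, though the retained chloro group should keep compound 3 well clear of that figure. The estimated step of a 94-fold higher number from compound 2 to compound 3 (1.97 log units; beyond the scatter) is accordingly sizeable. Compound 3 is expected to give 300 nM, within a range of 50 nM to 2000 nM.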

Compound 3, half-maximal inhibitory concentration: 41 nM
Estimate against measurement, compound 3: 7.3-fold (0.86 log units) above; measured number outside the range, below it.
By their numbers in this assay, from the lowest: compound 2; then compound 3; then compound 1.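

In this assay, chloro in place of hydrogen on an aromatic carbon, with isopropoxy held constant, gives a 200-fold lower number from compound 1 to compound 3 (2.30 log units; beyond the scatter) and so is a large gain on its own. With chloro held constant, isopropoxy in place of 3,5-dimethyl-1,2-oxazol-4-yl gives a 13-fold higher number from compound 2 to compound 3 (1.11 log units; beyond the scatter) and is also large, so the five-membered aromatic ring outperforms isopropoxy at this place. No measurement offered here explains either step.

As far as these compounds go, whether an amine, a carboxylic acid or a longer alkoxy chain would match 3,5-dimethyl-1,2-oxazol-4-yl at this place remains open. So does the effect of replacing chloro with another group, such as fluoro or methyl.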